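Piperidine to Pyrrolidine: One Ring Member Fewer

A few compounds are considered here, and "the series" means these few. Any claim that something is new, unique, unknown or untested is made for them only; others in the source may bear on it.

Measured in an assay for inhibition of Fatty-acid amide hydrolase 1 (Rattus norvegicus); on this read-out lower numbers stand for stronger inhibition and higher numbers for weaker inhibition:
Compound 1 `O=C(CCc1ccc(COc2ccccc2)cc1)c1ncco1`: 25 nM
Compound 2 `O=C(O)c1cccc(-c2cnc(C(=O)CCc3ccc(-c4ccc(CN5CCCCC5)cc4)cc3)o2)n1`: 44 nM

Among these two numbers, compound 2 gives the higher one. Within the data shown here, its only neighbour is compound 1, whose number is lower, but the gap between the two lies within the usual scatter of this kind of measurement, so no order between them can be claimed.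

Compound 3 `O=C(O)c1cccc(-c2cnc(C(=O)CCc3ccc(-c4ccc(CN5CCCC5)cc4)cc3)o2)n1` differs from compound 2 in a single place: pyrrolidin-1-yl in place of piperidin-1-yl on a saturated chain carbon bound to an aromatic carbon. Among the measured compounds shown here, no pair of measured compounds shows this change, so there is no measured step to lean on. The change is small in count and in kind, a five-membered ring in place of a six-membered one with the same donor and acceptor count, and the step from compound 2 is therefore expected to be small, in no clear direction, and to stay within the scatter, as expressed by a 1.0-fold higher number from compound 2 to compound 3 (0.01 log units; within the scatter). Compound 3 is accordingly estimated at 45 nM in this assay, with a range from 18 nM to 110 nM.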

Compound 3, inhibition constant: 130 nM
The estimate for compound 3 lay 2.9-fold (0.46 log units) below the measured number; the whole stated range lies below it.
By their numbers in this assay, from the lowest: compounds 1 and 2 (each within the scatter of the next); then compound 3.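

In this assay, pyrrolidin-1-yl in place of piperidin-1-yl on a saturated chain carbon bound to an aromatic carbon gives a 3.0-fold higher number from compound 2 to compound 3 (0.47 log units; beyond the scatter). Among these compounds, this is the first measured step at this place, and it shows that the read-out responds to the loss of one ring member even though the hydrogen-bond donor and acceptor counts of the two groups are the same. Nothing available explains why the number moves with this change.

The compounds shown leave open whether azepan-1-yl, with one ring member more, morpholin-4-yl or an open-chain dimethylamino group would hold the number of compound 2 or move it further. A single step also leaves open whether the same ring change would have a similar effect on a core without the carboxylic acid.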